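Methyl for trifluoromethyl on the shared core: one value pending

The source may hold more compounds than are shown below. What is called first, only, known or untested is meant among the compounds shown, and "the series" means these compounds.

Measured so far:
compound 1, `CN(C(=O)NC(=O)c1ccc(Cl)cc1Cl)c1nc(C(F)(F)F)c(C(=O)N/N=C/c2ccc(C(F)(F)F)cc2)s1`: 7.99 ug/mL in a functional assay on HeLa cells (Homo sapiens) for inhibition, read by MTT assay, with a stated time of 72 h; on this read-out lower numbers stand for stronger inhibition and higher numbers for weaker inhibition
compound 2, `CN(C(=O)NC(=O)c1c(F)cccc1F)c1nc(C(F)(F)F)c(C(=O)N/N=C/c2cccc(C(F)(F)F)c2)s1`: 21.6 ug/mL in this assay
compound 3, `Cc1nc(N(C)C(=O)NC(=O)c2c(F)cccc2F)sc1C(=O)N/N=C/c1cccc(C(F)(F)F)c1`: 26.8 ug/mL in this assay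

Compound 1 gives the lowest of the three numbers, and its gaps to compound 2 and to compound 3 both lie beyond the scatter. Compound 1 and compound 2 differ in more than one place; how their two cores differ is not broken down here.

Within the pair that shares a core, the change is methyl in place of trifluoromethyl on an aromatic carbon, and it made a 1.2-fold higher number from compound 2 to compound 3 (0.09 log units; within the scatter).

Compound 4, `Cc1nc(N(C)C(=O)NC(=O)c2ccc(Cl)cc2Cl)sc1C(=O)N/N=C/c1ccc(C(F)(F)F)cc1`, is not yet measured. It relates to compound 1 by methyl in place of trifluoromethyl on an aromatic carbon. The surroundings of the place are the same word for word as for the change from compound 2 to compound 3, so this is the same change, now made on the core of compound 1.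

For compound 4 in this assay the step is expected to be a 1.2-fold higher number from compound 1 to compound 4 (0.08 log units; within the scatter), resting on the near-flat step a 1.2-fold higher number from compound 2 to compound 3 (0.09 log units; within the scatter) seen for the same change. For the measured compounds named here, since compound 1 gives 7.99 ug/mL, compound 4 is expected to come in near 9.5 ug/mL, with a range from 5 ug/mL to 18 ug/mL; the single prior example leaves the expectation loosely held.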

Compound 4, half-maximal inhibitory concentration: 20.3 ug/mL
Estimate against measurement, compound 4: 2.1-fold (0.33 log units) below; measured number outside the range, above it.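

On the core of compound 1, methyl in place of trifluoromethyl gives a 2.5-fold higher number from compound 1 to compound 4 (0.40 log units; beyond the scatter) in this assay, and set beside the step on the other core, the two cannot be told apart: the same change on two cores in this assay, a 1.2-fold higher number (0.09 log units; within the scatter) from compound 2 to compound 3 and a 2.5-fold higher number (0.40 log units; beyond the scatter) from compound 1 to compound 4, 2.0-fold (0.31 log units) apart, within the scatter of two such steps

Read together, the two pairs fit one modest shared step carried across both cores, even though only the step on the core of compound 1 stands clear of the scatter on its own. They do not show that the step is the same on both cores, nor that it depends on the core: two pairs in a single assay cannot separate those readings, and a wider or narrower gap between the steps would need further matched pairs.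

The cores of compound 1 and compound 2 differ in more than one place, and no compound shown isolates any one of those places, so which of them might bear on the size of the step stays open. At the ring carbon itself, only trifluoromethyl and methyl appear, which leaves open how an amine, a carboxylic acid or a longer alkyl chain there would read out in this assay.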